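The compounds below may be only part of what the source reports. "The series", "measured", "known", "first", "only" and "open" are said of these compounds alone.

Measured so far in a functional assay on the whole organism with Mus musculus as the target, with a stated time of 4 h; on this read-out higher numbers stand for an effect only at larger amounts of compound and lower numbers for an effect already at smaller amounts:
compound 1 `Fc1ccc(/C=N/NC(=S)Nc2nc3ccc(Cl)cc3s2)cc1` gives 100 mg/kg.
compound 2 `O=C(Cn1ccc2ccccc21)Nc1nc2ccc(Cl)cc2s1` gives 300 mg/kg.
compound 3 `CC(C)(C)NCC(=O)Nc1nc2ccc(Cl)cc2s1` gives 300 mg/kg.

Compound 3 stands level with compound 2 at the digits shown; together they have the highest numbers of the three, so an effect appears only at the largest amounts. Compound 1 lies furthest away, with a lower number, a gap beyond the scatter.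

Compound 4 `O=C(Cn1ccnc1)Nc1nc2ccc(Cl)cc2s1` has not yet been tested. It differs from compound 3 in one place: 1H-imidazol-1-yl in place of (tert-butyl)amino on a saturated chain carbon bound to a carbonyl carbon. Among the measured compounds shown here, no measured pair shows this change, so the expectation rests on the numbers alone, and since compound 2 and compound 3 give the same figure, no shift beyond the scatter is expected: the expected step is no change at the digits printed from compound 3 to compound 4 (within the scatter). Compound 4 is therefore estimated at 300 mg/kg, within a range from 100 mg/kg to 1000 mg/kg.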

Compound 4, minimum effective dose: 100 mg/kg
Estimate against measurement, compound 4: 3.0-fold (0.48 log units) above; the range from low to high includes it.
By their numbers in this assay, from the lowest: compounds 1 and 4 (each within the scatter of the next); then compounds 2 and 3 (each within the scatter of the next).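

In this assay, 1H-imidazol-1-yl in place of (tert-butyl)amino on a saturated chain carbon bound to a carbonyl carbon gives a 3.0-fold lower number from compound 3 to compound 4 (0.48 log units; beyond the scatter) and so shows that the group at this place can shift the dose. Both groups hold 5 heavy atoms, so the step comes with a swap of an open group for an aromatic ring, not with a change in that count. Nothing available explains the step.

From the compounds shown here alone, whether a pyrrolidine or a 1,2,4-triazol-1-yl group would follow compound 3 or compound 4 remains open. So does whether 1H-imidazol-1-yl would give the same result on a longer chain.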